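Second occurrence of fluoro for trifluoromethyl: notes

This account rests on a few compounds, and the source may have more. Where it says the series, first, only, none or still open, it means among the compounds named here.

Measured so far:
compound 1, `O=S(=O)(/C=C/c1ccc(O)c(O)c1)NCc1ccc(C(F)(F)F)cc1`, gives 12600 nM in a functional assay on BV-2 cells (Mus musculus) for inhibition, read by Griess assay, with stated times of 3 h and 24 h; on this read-out lower numbers stand for stronger inhibition and higher numbers for weaker inhibition
compound 2, `O=S(=O)(/C=C/c1ccc(O)c(O)c1)NCc1ccc(F)cc1`, gives 18900 nM in this assay
compound 3, `CC(=O)Oc1ccc(/C=C/S(=O)(=O)NCc2ccc(C(F)(F)F)cc2)cc1OC(C)=O`, gives 9300 nM in this assay

Compound 1 and compound 2 share one core and differ at a single point: fluoro in place of trifluoromethyl on an aromatic carbon. That change gave a 1.5-fold higher number from compound 1 to compound 2 (0.18 log units; within the scatter). Compound 3 is built on a different core; how its core differs from that of compound 1 is not broken down here. Compound 3 shows the lowest number of the three, with compound 1 within the scatter of it and compound 2 beyond the scatter.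

Compound 4, `CC(=O)Oc1ccc(/C=C/S(=O)(=O)NCc2ccc(F)cc2)cc1OC(C)=O`, has not yet been measured in this assay. It derives from compound 3 by fluoro in place of trifluoromethyl on an aromatic carbon, which is the same change as from compound 1 to compound 2, described at a place in identical words. Because the earlier step was a 1.5-fold higher number from compound 1 to compound 2 (0.18 log units; within the scatter), a step of similar, modest size is expected for compound 4, namely a 1.5-fold higher number from compound 3 to compound 4 (0.18 log units; within the scatter). Compound 4 is therefore estimated at about 14000 nM, expected to fall between 7000 nM and 28000 nM.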

Compound 4, half-maximal inhibitory concentration: 15500 nM
Compound 4: middle estimate off by 1.1-fold (0.04 log units), on the low side; measured number inside the range.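

In this assay, fluoro in place of trifluoromethyl gives a 1.7-fold higher number from compound 3 to compound 4 (0.22 log units; within the scatter), so on the core of compound 3 the change again produces only a small step. Read on both cores, the change behaves alike, and the two steps cannot be told apart: the same change on two cores in this assay, a 1.5-fold higher number (0.18 log units; within the scatter) from compound 1 to compound 2 and a 1.7-fold higher number (0.22 log units; within the scatter) from compound 3 to compound 4, 1.1-fold (0.05 log units) apart, within the scatter of two such steps This shows that the change carries over between these two cores without a detectable difference in step size, but each step lies within the scatter, so neither step establishes a real effect of the change on its own, and two cores say nothing about how the change would behave on any other core.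

From the compounds shown here alone, the comparison covers only 4-(trifluoromethyl)phenyl and 4-fluorophenyl, so it remains open how a nitrile, an amine or a carboxylic acid in the same place would read in this assay. Going by these compounds, it also remains open whether a larger step would appear on a core other than those of compound 1 and compound 3.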